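The compounds below may be only part of what the source reports. "The series", "measured", "known", "first", "only" and "open" are said of these compounds alone.

Measured so far in an assay on isolated protein (Bos taurus) for binding affinity to Voltage-dependent L-type calcium channel subunit alpha-1C (Homo sapiens); a lower number here means a stronger inhibitor, a higher number a weaker inhibitor:
compound 1 `CCOC(=O)C1=C(C)NC(C)=C(C#N)[C@@H]1c1cnccc1-c1ccccc1`: 250 nM
compound 2 `CCOC(=O)C1=C(C)NC(C)=C(C#N)[C@@H]1c1cnccc1-c1ccc2ccccc2c1`: 100 nM

Within the data shown here, the only measured step is a 2.5-fold lower number from compound 1 to compound 2 (0.40 log units; beyond the scatter), which leaves compound 2 with the lower of the two numbers.

Compound 3 `CCOC(=O)C1=C(C)NC(C)=C(C#N)[C@@H]1c1cnccc1-c1cccc2ccccc12` differs from compound 2 by naphthalen-1-yl in place of naphthalen-2-yl on an aromatic carbon. Among the measured compounds shown here, no measured step bears on shifting the attachment point within the naphthyl group; the one step known, a 2.5-fold lower number from compound 1 to compound 2 (0.40 log units; beyond the scatter), concerns a different change and gives no direction here. The step expected in this assay is therefore none beyond the scatter, estimated as a 1.5-fold higher number from compound 2 to compound 3 (0.18 log units; within the scatter). Compound 3 is expected to give 150 nM in this assay, with a range of 50 nM to 500 nM.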

Compound 3, half-maximal inhibitory concentration: 270 nM
Compound 3: the middle estimate sits 1.8-fold (0.26 log units) below what was measured; the measured number falls inside the stated range.
By their numbers in this assay, from the lowest: compound 2; then compounds 1 and 3 (each within the scatter of the next).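

In this assay the attachment point of the naphthyl group at this position matters, with the same atoms joined differently: a 2.7-fold higher number from compound 2 to compound 3 (0.43 log units; beyond the scatter). Naphthalen-1-yl in place of phenyl gives a 1.1-fold higher number from compound 1 to compound 3 (0.03 log units; within the scatter), so added ring size alone does not carry the lower number of compound 2, and only naphthalen-2-yl stands apart from phenyl. No available data explain the difference between the two naphthyl groups.

Going by these compounds, it remains open whether a quinolin-3-yl or a 4-methoxyphenyl group at this position would match compound 2 or go beyond it.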